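Swapping Bromophenyl for Dichlorophenyl: Expected Cytotoxicity

The source may report more compounds than this note shows. Statements on the series, on what has been measured and on what is new or still open speak of the compounds shown alone.

compound 1 `CCOC(=O)CCCCCOc1cccc(CN(C(=O)c2ccc(-c3cccc(O)c3)cc2)C(C)C)c1`: > 26000 nM
compound 2 `CCOC(=O)CCCCCOc1cccc(CN(C(=O)c2ccc(-c3cccc(Br)c3)cc2)C(C)C)c1`: > 26000 nM

Of the compounds shown here, two sharing one core have so far been tested in an ADME assay on HEK293 cells (Homo sapiens) for cytotoxicity, read by CellTiter-Glo and resazurin assay, with a stated time of 72 h; on this read-out higher numbers stand for an effect only at larger amounts of compound and lower numbers for an effect already at smaller amounts. Compound 1 `CCOC(=O)CCCCCOc1cccc(CN(C(=O)c2ccc(-c3cccc(O)c3)cc2)C(C)C)c1` reaches only a limit of the assay, > 26000 nM. Compound 2 `CCOC(=O)CCCCCOc1cccc(CN(C(=O)c2ccc(-c3cccc(Br)c3)cc2)C(C)C)c1` likewise reaches only a limit of the assay, > 26000 nM. Going by the values given here, the single step between them, a step that the two limits leave unreadable from compound 1 to compound 2, has no readable size because of the limit of > 26000 nM in this assay, at which 2 of the 2 values shown sit.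

Compound 3 `CCOC(=O)CCCCCOc1cccc(CN(C(=O)c2ccc(-c3ccc(Cl)c(Cl)c3)cc2)C(C)C)c1` is not yet measured. It differs from compound 2 in that (3,4-dichlorophenyl in place of 3-bromophenyl on an aromatic carbon). Among the compounds with values here, no measured step gives a size for this kind of change, and the one step available is unreadable, so the expectation rests on the fact that both measured compounds sit at the same limit. In this assay compound 3 is therefore expected to stay at or near that limit, with a step that the limit leaves unreadable from compound 2 to compound 3 as the expected step, meaning no change beyond the scatter. Compound 3 is estimated at 40000 nM, within a range from 15000 nM to 150000 nM.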

Compound 3, half-maximal effective concentration: > 26000 nM
Compound 3 was reported as a limit; the forecaster's own chance of this, stated with the estimate: 75%; the middle value lies beyond the limit too.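

Going by these compounds alone, no step among compound 1, compound 2 and compound 3 can be read, because all three give only a limit rather than a true number: the limit of > 26000 nM in this assay, at which 3 of the 3 values shown sit.

As far as these compounds go, whether these compounds differ at all in this assay stays open, as does the amount, if any, at which each would harm the cells.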